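Taking the ethyl group off compound 2

A few compounds are considered here, and "the series" means these few. Any claim that something is new, unique, unknown or untested is made for them only; others in the source may bear on it.

Compound 1 (`O=C1CS/C(=N/Nc2nncc3ccccc23)N1c1ccccc1`) gives 44 nM
Compound 2 (`CCN1C(=O)CS/C1=N/Nc1nncc2ccccc12`) gives 65 nM
Compound 3 (`O=S(=O)(Nc1nccs1)c1ccc(Nc2nncc3ccccc23)cc1`) gives 36 nM

In a functional assay on MDA-MB-435 cells (Homo sapiens) for antiproliferative activity, read by sulforhodamine B assay, with a stated time of 72 h (on this read-out higher numbers stand for weaker inhibition and lower numbers for stronger inhibition), compound 2 stands at 65 nM and lies within the scatter of both compound 1 and compound 3. Compound 4 (`O=C1CS/C(=N/Nc2nncc3ccccc23)N1`) has hydrogen in place of ethyl on an amide-type nitrogen in a ring. Going by the values given here, only one measured step touches this nitrogen, ethyl in place of phenyl (a 1.5-fold higher number from compound 1 to compound 2 (0.17 log units; within the scatter)), and it stayed within the scatter. Among the compounds with values here, no measured compound carries hydrogen there, so that step is only a loose guide. A shift beyond the scatter is not expected in this assay in either direction, and the expected change is small (a 1.1-fold higher number from compound 2 to compound 4 (0.03 log units; within the scatter)). The estimate for compound 4 is 70 nM with 25 nM to 200 nM as its expected range.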

Compound 4, half-maximal inhibitory concentration: 56 nM
Estimate against measurement, compound 4: 1.3-fold (0.10 log units) above; low and high end bracket the measured number.
By their numbers in this assay, from the lowest: compounds 3, 1, 4 and 2 (each within the scatter of the next).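

Removing the ethyl group altogether changes little in this assay (a 1.2-fold lower number from compound 2 to compound 4 (0.06 log units; within the scatter)), and replacing the phenyl group with hydrogen also stays close (a 1.3-fold higher number from compound 1 to compound 4 (0.10 log units; within the scatter)). Hydrogen, ethyl and phenyl on this amide-type nitrogen therefore all read alike, so among these compounds a carbon group is not needed there for this activity. No measurement at hand explains why the three read alike. Still open, on these data alone, is whether a longer chain ending in an amine or a carboxylic acid at this nitrogen would stay in the same range.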